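Carbamate to urea: expected shift in cell inhibition

The source may hold more compounds than are shown below. What is called first, only, known or untested is meant among the compounds shown, and "the series" means these compounds.

Measured so far in a functional assay on U-373MG ATCC cells (Homo sapiens) for inhibition, read by MTT assay, with a stated time of 72 h; on this read-out higher numbers stand for weaker inhibition and lower numbers for stronger inhibition:
- compound 1 `O=[N+]([O-])c1cccc(NC(=S)NC2CCOc3ccc(Cl)cc32)c1`, which gives 8000 nM
- compound 2 `CCOC(=O)NC1CC(C)(C)Oc2ccc(Cl)cc21`, which gives > 100000 nM
- compound 3 `CC1(C)CC(NC(=S)Nc2cccc(C#N)c2)c2cc(Cl)ccc2O1`, which gives 7000 nM

The value for compound 2 is not a number but a limit of this assay, (the limit of > 100000 nM in this assay, at which 1 of the 3 values shown sits). Compound 2 is thus the only one of the three without a measured number, and it stands apart from the two thiourea compounds, which both carry an aryl group on the thiourea and both give numbers in this assay.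

The compound to be measured is compound 4 `CC1(C)CC(NC(=O)Nc2cccc(Cl)c2)c2cc(Cl)ccc2O1`. It differs from compound 2 in one place: (3-chlorophenyl)amino in place of ethoxy on a carbonyl carbon. The change turns the carbamate of compound 2 into a urea bearing an aryl group, which brings compound 4 closer in make-up to compound 1 and compound 3 than compound 2 is.

Going by the values given here, no step between measured compounds is available here, so the expectation rests on the spread of the values shown. With compound 1 and compound 3 both giving numbers and compound 2 only a limit, the step of an at least 8.3-fold lower number from compound 2 to compound 4 (0.92 log units; beyond the scatter) is expected to go towards stronger inhibition and to exceed the scatter. Compound 4 is therefore expected to give about 12000 nM in this assay, within a range from 3000 nM to 50000 nM.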

Compound 4, half-maximal inhibitory concentration: 21000 nM
Compound 4: the middle estimate sits 1.8-fold (0.24 log units) below what was measured; measured number inside the range.
By their numbers in this assay, from the lowest: compounds 3 and 1 (each within the scatter of the next); then compound 4. At a limit, above all of these: compound 2.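

In this assay compound 2 is held at a limit of the assay and not at a number: the limit of > 100000 nM in this assay, at which 1 of the 4 values shown sits.

From the compounds shown here alone, on this carbonyl carbon, (3-chlorophenyl)amino in place of ethoxy gives an at least 4.7-fold lower number from compound 2 to compound 4 (0.67 log units; beyond the scatter), so the position responds to the change, and the true size of the step stays unknown as one end is a limit. In this assay compound 4 gives 21000 nM, which shows that a measurable number in this series does not depend on a thiourea, the only linker that had given one so far.

The step cannot separate the aromatic ring from the hydrogen-bond donor, as both enter in the same swap, and compound 3 and compound 4 differ in more than one place, so the urea and thiourea linkers are not compared on their own. Also open, going by these compounds, is how a plain amine, an alkylamino group such as benzylamino, or a longer alkoxy chain such as butoxy would behave on the same carbonyl carbon, and whether the chlorine of the 3-chlorophenyl group matters at all.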